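Compound 3 follows two compounds held at a limit

The source may hold more compounds than are shown below. What is called first, only, known or untested is meant among the compounds shown, and "the series" means these compounds.

Measured compounds in a functional assay on Jurkat cells (Homo sapiens) for cytotoxicity, with a stated time of 72 h (a higher number here means that more compound is needed for the effect, a lower number that less compound is needed), are these.
Compound 1 `COc1ccc(/C=C/[C@@](C)(/C=C/c2ccc(O)c(/C=C/C#N)c2)CCC=C(C)C)cc1` gives > 49000 nM as a limit
Compound 2 `CCOC(=O)/C(C)=C/c1cc(/C=C/[C@](C)(/C=C/c2ccc(OC)cc2)CCC=C(C)C)ccc1O` gives > 49000 nM as a limit

Compound 2 thus stands only at a limit, with > 49000 nM as its entry in this assay and no number to read. Compound 3 `COc1ccc(/C=C/[C@@](C)(/C=C/c2ccc(O)c(/C=C/C(=O)OC(C)(C)C)c2)CCC=C(C)C)cc1` differs from compound 2 in one place 2-(tert-butoxycarbonyl)ethenyl in place of 2-(ethoxycarbonyl)prop-1-en-1-yl on an aromatic carbon where 2-(tert-butoxycarbonyl)ethenyl takes the place of 2-(ethoxycarbonyl)prop-1-en-1-yl on an aromatic carbon. Going by the values given here, the only measured step at this place is a step that the two limits leave unreadable from compound 1 to compound 2 and it has no readable size. Both measured compounds sit at the same limit of > 49000 nM in this assay, at which 2 of the 2 values shown sit, so no size can be carried over. No step beyond the scatter is therefore expected in this assay and another limit is the likeliest report. The estimated change is an at least 1.0-fold lower number from compound 2 to compound 3 (0.03 log units; that floor lies within the scatter) and no more than that is expected. For compound 3 the estimate is 45000 nM with an expected range from 18000 nM to 70000 nM overall.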

Compound 3, half-maximal effective concentration: > 49000 nM
Compound 3 was reported as a limit; the forecaster's own chance of this, stated with the estimate: 70%; middle value at least 1.0-fold (0.03 log units) away from the limit.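

Going by these compounds alone, compound 3 is also reported only as a limit, so no step among compound 1, compound 2 and compound 3 can be read: the limit of > 49000 nM in this assay, at which 3 of the 3 values shown sit. The compounds shown leave open whether the groups exchanged on the aromatic carbon differ at all in this assay.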